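Sulfonyl aryl swap at the cytotoxicity limit

A few compounds are considered here, and "the series" means these few. Any claim that something is new, unique, unknown or untested is made for them only; others in the source may bear on it.

In a functional assay on HEK293 cells (Homo sapiens) for cytotoxicity (a higher number here means that more compound is tolerated, a lower number that less compound is tolerated), compound 1 (`COc1ccc([C@H]2CC(=O)N(c3cccc(NS(=O)(=O)c4cc(C)ccc4OC)c3)C2)cc1OC1CCCC1`) gives > 10000 nM as a limit of the assay. Compound 2 (`COc1ccc([C@H]2CC(=O)N(c3cccc(NS(=O)(=O)c4c(F)cccc4F)c3)C2)cc1OC1CCCC1`) gives > 10000 nM as a limit too. Compound 2 therefore has no numerical position, only a shared limit (the limit of > 10000 nM in this assay, at which 2 of the 2 values shown sit). Among the compounds with values here, the one measured change on the sulfonyl sulfur, a step that the two limits leave unreadable from compound 1 to compound 2 in size, offers nothing to carry forward.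

Compound 3 (`COc1ccc([C@H]2CC(=O)N(c3cccc(NS(=O)(=O)c4cc(Br)c(Cl)s4)c3)C2)cc1OC1CCCC1`) has 4-bromo-5-chlorothiophen-2-yl in place of 2,6-difluorophenyl on a sulfonyl sulfur is the whole difference. Within the data shown here, with only that unreadable step as a guide, the expected move in this assay is none beyond the scatter, and a step that the limit leaves unreadable from compound 2 to compound 3 is estimated as small. For compound 3 the estimated value is 12000 nM with an expected range from 5000 nM to 30000 nM and another limit is the likeliest report.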

Compound 3, half-maximal cytotoxic concentration: > 10000 nM
Compound 3: a limit, no number; the forecaster's own chance of this, stated with the estimate: 70%; the middle value does not contradict the limit.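

Compound 3 also gives only a limit, so no step among compound 1, compound 2 and compound 3 can be read in this assay: the limit of > 10000 nM in this assay, at which 3 of the 3 values shown sit.

The compounds shown leave open whether any group on the sulfonyl sulfur of the shared core gives a readable number in this assay.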